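Hydroxymethyl for fluoro on a stable compound

A few compounds are considered here, and "the series" means these few. Any claim that something is new, unique, unknown or untested is made for them only; others in the source may bear on it.

compound 1 `C[C@]1(C(=O)O)CC[C@H](C(=O)N2CC[C@](c3ccc(C(F)(C(F)(F)F)C(F)(F)F)cc3)(S(=O)(=O)c3ccc(F)cc3)C2)CC1`: 97%
compound 2 `COC[C@]1(C(=O)N2CC[C@](c3ccc(C(F)(C(F)(F)F)C(F)(F)F)cc3)(S(=O)(=O)c3ccc(F)cc3)C2)CC[C@H](C(=O)O)CC1`: 100%
compound 3 `O=C(N1CC[C@](c2ccc(C(F)(C(F)(F)F)C(F)(F)F)cc2)(S(=O)(=O)c2ccc(F)cc2)C1)C1(F)CCS(=O)(=O)CC1`: 100%

In an ADME assay on microsomes from liver (Homo sapiens) for metabolic stability, with a stated time of 10 min (on this read-out higher numbers stand for a more stable compound and lower numbers for a less stable compound), compound 3 gives 100%, level with compound 2 and within the scatter of compound 1. Compound 4 `O=C(N1CC[C@](c2ccc(C(F)(C(F)(F)F)C(F)(F)F)cc2)(S(=O)(=O)c2ccc(F)cc2)C1)C1(CO)CCS(=O)(=O)CC1` carries hydroxymethyl in place of fluoro on a saturated ring carbon. Going by the values given here, no measured step makes this exact swap. The closest evidence comes from exchanging the whole group on the carbonyl carbon: a number 3 percentage points higher from compound 1 to compound 3 (within the scatter), no change at the digits printed from compound 2 to compound 3 (within the scatter) and a number 3 percentage points higher from compound 1 to compound 2 (within the scatter). Going by these compounds, none of these leaves the scatter, so no large step is expected, although hydroxymethyl itself is untested in this set. The estimated step is small and downward: a number 5 percentage points lower from compound 3 to compound 4 (within the scatter). The estimate for compound 4 is 95%, with an expected range from 83% to 100%.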

Compound 4, percent of the compound remaining: 75%
Estimate against measurement, compound 4: 20 percentage points above, and the stated range ends above it.
By their numbers in this assay, from the lowest: compound 4; then compounds 1, 2 and 3 (each within the scatter of the next).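

In this assay, going by these compounds alone, the saturated ring carbon three ring bonds from the ring sulfur turns out to be sensitive to its substituent: hydroxymethyl in place of fluoro gives a number 25 percentage points lower from compound 3 to compound 4 (beyond the scatter) and is the first change here to leave the scatter. With a number 25 percentage points lower from compound 2 to compound 4 (beyond the scatter) and a number 22 percentage points lower from compound 1 to compound 4 (beyond the scatter) as well, compound 4 stands lowest of the four. Nothing shown explains this step. Going by these compounds, whether an aminomethyl group or a longer hydroxyethyl chain on this ring carbon would behave like fluoro or like hydroxymethyl stays open.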